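The source may hold more compounds than are shown below. What is called first, only, known or untested is meant among the compounds shown, and "the series" means these compounds.

Measured in a functional assay on the whole organism (strain Kunming) with Mus musculus as the target, with a stated time of 0.5 h; on this read-out lower numbers stand for an effect already at smaller amounts and higher numbers for an effect only at larger amounts of compound:
- compound 1 `COc1cc(OC)c(OC)cc1/C=C/COC(=O)/C=C/c1c(OC)ccc(OC)c1OC`: 53.5 mg/kg
- compound 2 `COc1cc(OC)c(OC)cc1/C=C/COC(=O)/C=C/c1cc(OC)c(OC)c(OC)c1OC`: 30.9 mg/kg
- compound 3 `COc1cc(OC)c(OC)cc1/C=C/COC(=O)/C=C/c1ccccc1C(F)(F)F`: 85.7 mg/kg

Compound 3 lies within the scatter of compound 1, and its number stands above that of compound 2 by more than the scatter. In compound 4 `COc1cccc(/C=C/C(=O)OC/C=C/c2cc(OC)c(OC)cc2OC)c1`, 3-methoxyphenyl takes the place of 2-(trifluoromethyl)phenyl on a double-bonded chain carbon bound to a double-bonded chain carbon (3-methoxyphenyl in place of 2-(trifluoromethyl)phenyl on a double-bonded chain carbon bound to a double-bonded chain carbon). Going by the values given here, no measured step isolates this change. Compound 2, with methoxy groups on the aromatic ring at that place, gives 30.9 mg/kg, so a modest move towards a lower number in this assay is expected. The expected size is a 1.7-fold lower number from compound 3 to compound 4 (0.23 log units; within the scatter), estimated to stay within the scatter. For compound 4 the estimated value is 50 mg/kg, with an expected range of 25 mg/kg to 100 mg/kg.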

Compound 4, dose for half-maximal effect: 72.9 mg/kg
For compound 4 the middle estimate is 1.5-fold (0.16 log units) below the measured one, and the stated range covers the measured number.
By their numbers in this assay, from the lowest: compounds 2, 1, 4 and 3 (each within the scatter of the next, the first and the last beyond it).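

In this assay, going by these compounds alone, 3-methoxyphenyl in place of 2-(trifluoromethyl)phenyl on a double-bonded chain carbon bound to a double-bonded chain carbon gives a 1.2-fold lower number from compound 3 to compound 4 (0.07 log units; within the scatter), the only step read at this position so far. The two groups are therefore not told apart at this place, even though 3-methoxyphenyl carries a hydrogen-bond acceptor and 2-(trifluoromethyl)phenyl carries none. Nothing on hand explains this outcome. Going by these compounds, it remains open whether an amine or a carboxylic acid on this aromatic ring would carry the number beyond the scatter from compound 3.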